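The source may report more compounds than this note shows. Statements on the series, on what has been measured and on what is new or still open speak of the compounds shown alone.

Of the compounds shown here, three have been measured in a functional assay on MCF7 cells (Homo sapiens) for antiproliferative activity, read by MTT assay, with a stated time of 48 h; a lower number here means a stronger inhibitor, a higher number a weaker inhibitor. Compound 1 `COc1ccc(-c2c(Nc3cc(OC)c(OC)c(OC)c3)c3ccc(OC)cc3oc2=O)cc1` gives 89500 nM. Compound 2 `COc1ccc(-c2c(Nc3ccc(F)cc3)c3ccc(OC)cc3oc2=O)cc1` gives only a limit of the assay, > 100000 nM. Compound 3 `COc1ccc(-c2c(Nc3cc(OC)c(OC)c(OC)c3)c3ccc(O)cc3oc2=O)cc1` gives 56000 nM.

Compound 1 and compound 3 share the same core and differ in one place: hydrogen in place of methyl on an oxygen on an aromatic ring. That change produced a 1.6-fold lower number from compound 1 to compound 3 (0.20 log units; within the scatter), so the two numbers stand within the usual scatter of each other and no order between them can be claimed. Compound 2 carries a different core; how the core of compound 2 differs from the core of compound 1 is not broken down here. Compound 2 sits at the limit of > 100000 nM in this assay, at which 1 of the 3 values shown sits.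

Compound 4 `COc1ccc(-c2c(Nc3ccc(F)cc3)c3ccc(O)cc3oc2=O)cc1` has not yet been measured in this assay. It differs from compound 2 by hydrogen in place of methyl on an oxygen on an aromatic ring, the same kind of change as that between compound 1 and compound 3, at a place described in the same words. Because the earlier change gave a 1.6-fold lower number from compound 1 to compound 3 (0.20 log units; within the scatter), compound 4 is expected to move from compound 2 by about a step that the limit leaves unreadable from compound 2 to compound 4. Compound 4 is estimated at 120000 nM, most likely between 60000 nM and 300000 nM, and it is expected that the assay will again report only a limit for compound 4.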

Compound 4, half-maximal inhibitory concentration: 71500 nM
Estimate against measurement, compound 4: 1.7-fold (0.22 log units) above; the measured number falls inside the stated range.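

The methoxy to hydroxy change, carried over to a second core, gave an at least 1.3-fold lower number from compound 2 to compound 4 (0.14 log units; that floor lies within the scatter) in this assay. Neither this step nor the earlier one is shown to go beyond the usual scatter, so the pair does not establish that the change has a real effect on either core, and it does not establish that the effect differs from one core to the other: the same change on two cores in this assay, a 1.6-fold lower number (0.20 log units; within the scatter) from compound 1 to compound 3 and an at least 1.3-fold lower number (0.14 log units; that floor lies within the scatter) from compound 2 to compound 4; the limit leaves it open whether they differ The reading on the second core rests on compound 2, whose > 100000 nM is a limit of the assay and not a number, so the full size of that step stays unknown: the limit of > 100000 nM in this assay, at which 1 of the 4 values shown sits.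

The compounds shown leave open how a longer chain on that oxygen would compare with methoxy and hydroxy on either core. They also leave open whether an amine or a carboxylic acid in place of the hydroxy would give a step that can be told from the scatter.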